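A few compounds are considered here, and "the series" means these few. Any claim that something is new, unique, unknown or untested is made for them only; others in the source may bear on it.

Compound 1 `CC(C)(C)Cn1cc2c(Cl)nc(NC(=O)c3ccccc3)nc2n1` gives 30300 nM in an assay on CHO cells for displacement of a labelled ligand from adenosine receptor A3 (Homo sapiens), read by scintillation counting, with a stated time of 3 h; on this read-out higher numbers stand for weaker inhibition and lower numbers for stronger inhibition.
Compound 2 `CC(C)n1cc2c(Cl)nc(NC(=O)c3ccccc3)nc2n1` gives 12800 nM in this assay.

Compound 1 stands highest of the two numbers in this assay; its nearest neighbour is compound 2, reached by a 2.4-fold lower number from compound 1 to compound 2 (0.37 log units; beyond the scatter). Compound 3 `CC(C)(C)Cn1cc2c(Cl)nc(NC(=O)c3ccc(C(F)(F)F)cc3)nc2n1` differs from compound 1 by trifluoromethyl in place of hydrogen on an aromatic carbon. For the measured compounds named here, the single measured step changes the group on the aromatic nitrogen, not the benzamide ring, so no measured step bears on this change. The expected step is therefore a 1.2-fold lower number from compound 1 to compound 3 (0.08 log units; within the scatter), not beyond the scatter. Compound 3 is estimated at 25000 nM, with a range from 8000 nM to 80000 nM.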

Compound 3, inhibition constant: 6600 nM
Beside the measured number, compound 3's estimate is 3.8-fold (0.58 log units) above it, and the stated range ends above it.
By their numbers in this assay, from the lowest: compounds 3 and 2 (each within the scatter of the next); then compound 1.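

Trifluoromethyl in place of hydrogen on the six-membered aromatic ring of carbon only, para to a large group, gives a 4.6-fold lower number from compound 1 to compound 3 (0.66 log units; beyond the scatter) in this assay and so shows that this position, untouched by the earlier compounds, responds to substitution. This step is larger than the only earlier one, which changed the group on the aromatic nitrogen. No evidence here accounts for the change. As far as these compounds go, whether a nitrile, a methoxy group or a chlorine at this position would do the same remains open. So does whether trifluoromethyl has a similar effect with the isopropyl group of compound 2.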